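The source may hold more compounds than are shown below. What is called first, only, known or untested is meant among the compounds shown, and "the series" means these compounds.

Measured so far:
compound 1, `Fc1ccc2nc(-c3cncnc3)n(C3CC3)c2c1`: 40 nM
compound 2, `Fc1ccc2nc(-c3cnccn3)n(C3CC3)c2c1`: 541 nM
compound 3, `Fc1cc2nc(-c3cncnc3)n(C3CC3)c2cc1F`: 22 nM

In an assay on cells for inhibition of cytochrome P450 11B2, mitochondrial (Homo sapiens), read by HPLC, with a stated time of 90 min (on this read-out lower numbers stand for stronger inhibition and higher numbers for weaker inhibition), compound 3 gives the lowest number of the three, but its gap to compound 1 lies within the scatter, so the two cannot be ordered against each other. Only compound 2 stands clearly apart, as the step of a 14-fold higher number from compound 1 to compound 2 (1.13 log units; beyond the scatter) shows. The other measured step, a 1.8-fold lower number from compound 1 to compound 3 (0.26 log units; within the scatter), adds a fluoro to the core and stays within the scatter.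

Compound 4, `Cc1ncncc1-c1nc2cc(F)c(F)cc2n1C1CC1`, is not yet measured. It differs from compound 3 in one place: methyl in place of hydrogen on an aromatic carbon. Within the data shown here, no measured step touches this position or adds a methyl anywhere. The heteroaryl exchange of a 14-fold higher number from compound 1 to compound 2 (1.13 log units; beyond the scatter) is a different kind of change and offers no direct guide; the fluoro step of a 1.8-fold lower number from compound 1 to compound 3 (0.26 log units; within the scatter) shows only that a small substituent on the core left the number essentially unchanged. Among the measured compounds shown here, with no matching precedent, the working assumption is no change beyond the scatter. For compound 4 the expected step is a 1.4-fold higher number from compound 3 to compound 4 (0.13 log units; within the scatter). For compound 4 the estimate in this assay is 30 nM, with a range from 10 nM to 90 nM.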

Compound 4, half-maximal inhibitory concentration: 17 nM
For compound 4 the middle estimate is 1.8-fold (0.25 log units) above the measured one; the range from low to high includes it.
By their numbers in this assay, from the lowest: compounds 4, 3 and 1 (each within the scatter of the next, the first and the last beyond it); then compound 2.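

Working notes on the pyrimidine ring: in this assay, the exchange pyrimidin-5-yl to 4-methylpyrimidin-5-yl gives a 1.3-fold lower number from compound 3 to compound 4 (0.11 log units; within the scatter), so compound 3 and compound 4 cannot be told apart on this read-out. This is the first change shown on the ring itself rather than an exchange of the ring: a methyl on this aromatic carbon, next to the ring nitrogen and ortho to a large group, leaves the number within the scatter, whereas the ring exchange a 14-fold higher number from compound 1 to compound 2 (1.13 log units; beyond the scatter) lies beyond it. The compounds shown offer no independent measurement that could explain this outcome at the position.

Going by these compounds, one methyl gives a single point at this position, so it remains open whether an ethyl, a methoxy, an amine or a carboxylic acid on the same carbon would also stay within the scatter of compound 3. Also open, on these data alone, is whether the methyl reads the same on the core of compound 1, and whether the remaining ring carbons of the pyrimidin-5-yl group accept a methyl in the same way.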